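Chloro in place of nitro on the aryl tail

The compounds below may be only part of what the source reports. "The series", "measured", "known", "first", "only" and "open" are said of these compounds alone.

compound 1, `O=C1NC(=O)/C(=C/c2ccc(OCCSc3nnc(Cc4ccccc4)[nH]3)cc2)S1`: 28.5%
compound 2, `O=C1NC(=O)/C(=C/c2ccc(OCCSc3nnc(-c4ccc([N+](=O)[O-])cc4)[nH]3)cc2)S1`: 16%

Of the compounds shown here, two sharing one core have been measured in a functional assay on the whole organism (plasma, strain Wistar) with Rattus norvegicus as the target, with a stated time of 15 days, at a dose of 30 mg/kg by the oral route; on this read-out lower numbers stand for a weaker effect and higher numbers for a stronger effect at the one dose given. Compound 1 gives 28.5%, and compound 2 gives 16%. Compound 2 thus stands lowest of the two numbers, with compound 1 above it by a number 12.5 percentage points lower from compound 1 to compound 2 (beyond the scatter). Within the data shown here, that step, benzyl to 4-nitrophenyl, is the only measured step so far.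

The next compound is compound 3, `O=C1NC(=O)/C(=C/c2ccc(OCCSc3nnc(-c4ccc(Cl)cc4)[nH]3)cc2)S1`. It differs from compound 2 in one place: chloro in place of nitro on an aromatic carbon. Among the measured compounds shown here, no measured step touches this exchange, since the one step known swaps a benzyl for a 4-nitrophenyl group and never alters a substituent on that ring. For the measured compounds named here, the only guidance is that both measured values sit in the lower range of this assay, and the new group leaves the aryl ring in place. For compound 3 a step of about a number 6 percentage points higher from compound 2 to compound 3 (within the scatter) is expected, a small rise that may well stay within the scatter. Compound 3 is therefore estimated to give 22%, with a range from 8% to 36%.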

Compound 3, a percentage reported as activity, at one dose (the size of the read-out at that dose, not a potency): 23.7%
Compound 3: the middle estimate sits 1.7 percentage points below what was measured; the range from low to high includes it.
By their numbers in this assay, from the lowest: compounds 2, 3 and 1 (each within the scatter of the next, the first and the last beyond it).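

In this assay, chloro in place of nitro on the aromatic ring, at the place para to a large group, gives a number 7.7 percentage points higher from compound 2 to compound 3 (within the scatter), so exchanging these two groups, one of three heavy atoms and one of a single heavy atom, produces no readable difference. The other comparison, 4-chlorophenyl in place of benzyl, gives a number 4.8 percentage points lower from compound 1 to compound 3 (within the scatter), which shows that the clear gap between compound 1 and compound 2 does not carry over to every 4-substituted phenyl group: compound 3 cannot be told apart from either of them, even though those two can be told apart from each other. No measurement is available here that would explain these results.

The compounds shown leave open whether an amine or a carboxylic acid at this place on the ring would move the read-out beyond the usual scatter. They also leave open what a plain phenyl ring or a longer chain in place of benzyl would give, and with only one dose, they say nothing about potency.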